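Pyrrolidine for piperidine on two related cores

A few compounds are considered here, and "the series" means these few. Any claim that something is new, unique, unknown or untested is made for them only; others in the source may bear on it.

Compound 1 `CN(c1ccc(Oc2ncnc3sccc23)cc1)c1nccc(N2CCCC2)n1` and compound 2 `CN(c1ccc(Oc2ncnc3sccc23)cc1)c1nccc(N2CCCCC2)n1` share one core; in a functional assay on MDA-MB-231 cells (Homo sapiens) for inhibition, read by MTT assay, with a stated time of 72 h, tested at 20 uM (a higher number here means more inhibition at the concentration tested (going by the name of the read-out), a lower number less inhibition), compound 1 gives 31% and compound 2 gives 29.3%. The step of a number 1.7 percentage points higher from compound 2 to compound 1 (within the scatter) corresponds to pyrrolidin-1-yl in place of piperidin-1-yl on an aromatic carbon. Compound 3 `c1cc(N2CCCCC2)nc(Nc2ccc(Oc3ncnc4ccsc34)cc2)n1` is built on a second core; the difference between the two cores is not broken down here. In this assay compound 3 gives 45.7%, the highest of the three measured values, with the values of compound 1 and compound 2 both beyond the scatter below it. Compound 4 `c1cc(N2CCCC2)nc(Nc2ccc(Oc3ncnc4ccsc34)cc2)n1` is not yet measured; it differs from compound 3 by pyrrolidin-1-yl in place of piperidin-1-yl on an aromatic carbon, the same change as from compound 2 to compound 1. The expected step is small, a number 0.3 percentage points higher from compound 3 to compound 4 (within the scatter), because the earlier step of a number 1.7 percentage points higher from compound 2 to compound 1 (within the scatter) stayed within the scatter. Compound 4 is therefore estimated at 46%, between 33% and 59%.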

Compound 4, a percentage reported as inhibition, at one concentration (the size of the read-out at that concentration, not a potency): 14.3%
Compound 4: the middle estimate sits 31.7 percentage points above what was measured; measured number below the stated range.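

On the second core, pyrrolidin-1-yl in place of piperidin-1-yl gives a number 31.4 percentage points lower from compound 3 to compound 4 (beyond the scatter) in this assay, so the step read on the first core does not predict the step on the second. The two steps differ: the same change on two cores in this assay, a number 1.7 percentage points higher (within the scatter) from compound 2 to compound 1 and a number 31.4 percentage points lower (beyond the scatter) from compound 3 to compound 4, 33.1 percentage points apart, beyond the scatter of two such steps

The result shows that the outcome of this change depends on the core in these two pairs; it does not show which difference between the cores is responsible, and it rests on two pairs only.

Open, on these data alone, is whether the same dependence on the core appears with other groups at this place, such as morpholin-4-yl, azepan-1-yl or an open-chain dimethylamino group. Also open is how compound 3 and compound 4 compare across a range of concentrations, as a full concentration-response comparison is not among the data shown.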